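The source may hold more compounds than are shown below. What is called first, only, known or untested is meant among the compounds shown, and "the series" means these compounds.

Compound 1 `c1ccc(C2=NN(c3ccc(-c4ccccc4)nn3)C(c3ccccc3)C2)cc1` gives 40900 nM in a functional assay on Caco-2 cells (Homo sapiens) for antiproliferative activity, read by MTT assay, with a stated time of 24 h; a higher number here means a weaker inhibitor, a lower number a stronger inhibitor. Compound 2 `Fc1ccc(C2CC(c3ccccc3)=NN2c2ccc(-c3ccccc3)nn2)cc1`, bearing fluoro in place of hydrogen on an aromatic carbon, gives 10000 nM in this assay; this is a 4.1-fold lower number from compound 1 to compound 2 (0.61 log units; beyond the scatter). Compound 3 `Fc1ccc(C2CC(c3ccc(Cl)cc3)=NN2c2ccc(-c3ccccc3)nn2)cc1`, bearing chloro in place of hydrogen on an aromatic carbon, reaches in this assay only a limit, > 100000 nM, namely (the limit of > 100000 nM in this assay, at which 1 of the 3 values shown sits). That is an at least 10-fold higher number from compound 2 to compound 3 (1.00 log units; beyond the scatter). So compound 3 stands at the upper edge of the numbers shown, with no definite value of its own.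

Compound 4 `COc1cc(C2CC(c3ccc(Cl)cc3)=NN2c2ccc(-c3ccccc3)nn2)cc(OC)c1OC` differs from compound 3 by 3,4,5-trimethoxyphenyl in place of 4-fluorophenyl on a saturated ring carbon. Neither measured step touched this group: the two steps altered a single substituent on an aromatic ring, whereas here the whole aryl group is exchanged. For the measured compounds named here, they show only that small changes move the number by a modest to at least modest amount, in either direction. Compound 4 is therefore expected to show an at least 2.0-fold lower number from compound 3 to compound 4 (0.30 log units; that floor lies within the scatter), with a wide range. The estimate for compound 4 in this assay is 50000 nM, between 5000 nM and 300000 nM.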

Compound 4, half-maximal inhibitory concentration: > 100000 nM
Compound 4: no number, only a limit; the forecaster's own chance of this, stated with the estimate: 40%; at least 2.0-fold (0.30 log units) between middle value and limit.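

In this assay compound 3 and compound 4 both reach only a limit, so no step between them can be read: the limit of > 100000 nM in this assay, at which 2 of the 4 values shown sit.

The compounds shown leave open whether 3,4,5-trimethoxyphenyl in place of 4-fluorophenyl moves the number at all, and in which direction.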